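The source may report more compounds than this note shows. Statements on the series, on what has been measured and on what is new or still open speak of the compounds shown alone.

Of the compounds shown here, three have been tested so far in a functional assay with Rattus norvegicus as the target; a higher number here means that more compound is needed for the effect, a lower number that less compound is needed: compound 1 `CC(C)(C)c1ccc(C/N=C(\S)NC(c2ccccc2)c2ccc(NS(C)(=O)=O)cc2)cc1`, compound 2 `CCCC(/N=C(\S)NCc1ccc(C(C)(C)C)cc1)c1ccc(NS(C)(=O)=O)cc1` and compound 3 `C[C@@H](/N=C(\S)NCc1ccc(C(C)(C)C)cc1)c1ccc([N+](=O)[O-])cc1`. Compound 1 gives > 100000 nM, which is a limit of the assay and not a number. Compound 2 gives > 100000 nM, again a limit. Compound 3 gives > 100000 nM, also a limit. Compound 3 therefore has no number of its own, and its place is shared with the other two: the limit of > 100000 nM in this assay, at which 3 of the 3 values shown sit.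

The next compound, compound 4 `C[C@@H](/N=C(\S)NCc1ccc(C(C)(C)C)cc1)c1ccccc1`, has hydrogen in place of nitro on an aromatic carbon of compound 3, para to a large group: hydrogen in place of nitro on an aromatic carbon. Among the compounds with values here, no two measured compounds differ in only one place, so no measured step shows how large such a change might be. The expectation is therefore no clear shift in either direction, and another limit in place of a number would be no surprise. The expected change is a number no higher from compound 3 to compound 4 (the limit leaves the size open). Compound 4 is estimated at 100000 nM, with an expected range from 30000 nM to 300000 nM.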

Compound 4, half-maximal effective concentration: > 100000 nM
Compound 4: only a limit was reported (the forecaster's own chance of this, stated with the estimate: 70%); the middle value sits exactly at the limit.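

Compound 4 gives > 100000 nM as a limit of the assay and not a number. Compound 3 also stands at a limit, so no step can be read between compound 3 and compound 4. The compounds shown leave open which change would give a real number in this assay as all of them share one place: the limit of > 100000 nM in this assay, at which 4 of the 4 values shown sit.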